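Removing the N-aryl group from two oxazinone scaffolds

The compounds below may be only part of what the source reports. "The series", "measured", "known", "first", "only" and "open" are said of these compounds alone.

The measured compounds are these. Compound 1 `COc1ncc(-c2ccc3c(c2)NC(=O)CO3)cc1NS(=O)(=O)c1ccc(F)cc1` in a functional assay on HeLa cells (Homo sapiens) for antiproliferative activity, read by MTT assay, with a stated time of 72 h (a higher number here means a weaker inhibitor, a lower number a stronger inhibitor), gives 7110 nM. Compound 2 `COc1cccc(N2C(=O)COc3ccc(-c4cnc(OC)c(NS(=O)(=O)c5ccc(F)cc5)c4)cc32)c1` in this assay gives only a limit, > 40000 nM. Compound 3 `COc1cccc(N2C(=O)COc3ccc(-c4ccc(O)cc4)cc32)c1` in this assay likewise gives only a limit, > 40000 nM.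

The step from compound 2 to compound 1 is hydrogen in place of 3-methoxyphenyl on an amide-type nitrogen in a ring and gave an at least 5.6-fold lower number from compound 2 to compound 1 (0.75 log units; beyond the scatter). Its true size is not fixed, because compound 2 sits at the limit of > 40000 nM in this assay, at which 2 of the 3 values shown sit.

Compound 4 `O=C1COc2ccc(-c3ccc(O)cc3)cc2N1` is not yet measured. Among the compounds with values here, it differs from compound 3 by hydrogen in place of 3-methoxyphenyl on an amide-type nitrogen in a ring, the same change as the one from compound 2 to compound 1, made in the same place. How the core of compound 3 differs from that of compound 2 is not broken down here; compound 3 lacks the methoxypyridine sulfonamide arm that compound 1 and compound 2 carry.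

The expected step for compound 4 is an at least 1.6-fold lower number from compound 3 to compound 4 (0.20 log units; that floor lies within the scatter), resting on the step from compound 2 to compound 1 being an at least 5.6-fold lower number from compound 2 to compound 1 (0.75 log units; beyond the scatter) and on compound 3 standing at a limit. Because compound 3 sits at the limit of > 40000 nM in this assay, at which 2 of the 3 values shown sit, a limit for compound 4 remains quite possible. Compound 4 is estimated at 25000 nM, within 6000 nM to 40000 nM.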

Compound 4, half-maximal inhibitory concentration: > 40000 nM
Compound 4: a limit, no number; the forecaster's own chance of this, stated with the estimate: 55%; at least 1.6-fold (0.20 log units) between middle value and limit.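

Compound 3 and compound 4 each give only a limit in this assay, so no size can be read for the step between them: the limit of > 40000 nM in this assay, at which 3 of the 4 values shown sit.

The compounds shown leave open where the true values of compound 3 and compound 4 lie, and whether removing 3-methoxyphenyl lowers the number there as it does for compound 2 and compound 1.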